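This account rests on a few compounds, and the source may have more. Where it says the series, first, only, none or still open, it means among the compounds named here.

Compound 1 `C/C=C\C=C\[C@](C)(O)C/C=C/[C@H]1[C@H](O)CC(=O)[C@@H]1CC/C=C\CCC(=O)OC`: 0.0000099 mg/kg
Compound 2 `COC(=O)CC/C=C\CC[C@H]1C(=O)C[C@@H](O)[C@@H]1/C=C/C[C@@](C)(O)/C=C/C=C(C)C`: 0.00006 mg/kg

Both numbers come from a functional assay on the whole organism with Canis familiaris (Canis lupus familiaris) as the target; a lower number here means that less compound is needed, a higher number that more compound is needed for the effect. Within the data shown here, compound 2 stands at the higher of the two numbers; the only measured step, a 6.1-fold higher number from compound 1 to compound 2 (0.78 log units; beyond the scatter), lies beyond the scatter.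

Compound 3 `COC(=O)CC/C=C\CC[C@H]1C(=O)C[C@@H](O)[C@@H]1/C=C/C[C@@](C)(O)/C=C/C1=CCCC1` has not yet been measured in this assay. It differs from compound 2 in one place: cyclopent-1-en-1-yl in place of 2-methylprop-1-en-1-yl on a double-bonded chain carbon bound to a double-bonded chain carbon. Among the measured compounds shown here, the one measured step, a 6.1-fold higher number from compound 1 to compound 2 (0.78 log units; beyond the scatter), alters the same place but in a different way, so it bears on the new change only loosely, and no measured pair contains the cyclopent-1-en-1-yl group. For the measured compounds named here, because the only guide is a 6.1-fold higher number from compound 1 to compound 2 (0.78 log units; beyond the scatter), a change at that place of modest size, compound 3 is expected to give a number near that of compound 2, with an expected step of no change at the digits printed from compound 2 to compound 3 (within the scatter) that need not exceed the scatter. The estimate for compound 3 is 0.00006 mg/kg, within a range from 0.00002 mg/kg to 0.0002 mg/kg.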

Compound 3, dose for half-maximal effect: 0.00002 mg/kg
Compound 3: middle estimate off by 3.0-fold (0.48 log units), on the high side; measured number inside the range.
By their numbers in this assay, from the lowest: compound 1; then compound 3; then compound 2.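

In this assay, this place on a double-bonded chain carbon bound to a double-bonded chain carbon accepts a ring: cyclopent-1-en-1-yl in place of 2-methylprop-1-en-1-yl gives a 3.0-fold lower number from compound 2 to compound 3 (0.48 log units; beyond the scatter). The ring, although it has more heavy atoms than the group it replaces, lowers the number, so among these two groups the heavy-atom count does not rise with the number, yet prop-1-en-1-yl still stands lowest, with a 2.0-fold higher number from compound 1 to compound 3 (0.31 log units; beyond the scatter). No evidence is available on why the ring shifts the number in this way.

The compounds shown leave open whether a saturated cyclopentyl or a phenyl group at this place would behave like cyclopent-1-en-1-yl. They also leave open whether any group here could reach a number below that of compound 1.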